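Aryl variation on the shared core: PC-3 antiproliferation notes

This account rests on a few compounds, and the source may have more. Where it says the series, first, only, none or still open, it means among the compounds named here.

Measured so far:
- compound 1, `COc1cc(C2=NN(C(C)=O)C(c3ccccc3C(F)(F)F)O2)cc(OC)c1OC`: -11%
- compound 2, `COc1cc(C2=NN(C(C)=O)C(c3cccc(OC)c3OC)O2)cc(OC)c1OC`: 35%
- compound 3, `COc1cc(C2=NN(C(C)=O)C(c3cc(Cl)cc(Cl)c3)O2)cc(OC)c1OC`: 52.7%

All three were run in a functional assay on PC-3 cells (Homo sapiens) for antiproliferative activity, read by MTT assay, tested at 1 uM; a higher number here means a stronger effect of the compound at the concentration tested, a lower number a weaker effect. Compound 3 stands highest of the three numbers; compound 2 is nearest, a gap of a number 17.7 percentage points higher from compound 2 to compound 3 (beyond the scatter), and compound 1 is furthest, a gap of a number 63.7 percentage points higher from compound 1 to compound 3 (beyond the scatter). Between compound 1 and compound 2 the step is a number 46 percentage points higher from compound 1 to compound 2 (beyond the scatter).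

Compound 4, `COc1cc(C2=NN(C(C)=O)C(c3ccc(Cl)c([N+](=O)[O-])c3)O2)cc(OC)c1OC`, is not yet measured. The change from compound 3 is 4-chloro-3-nitrophenyl in place of 3,5-dichlorophenyl on a saturated ring carbon. Within the data shown here, the steps that bear on it are those that exchange the aryl group on the same saturated ring carbon: a number 63.7 percentage points higher from compound 1 to compound 3 (beyond the scatter) and a number 17.7 percentage points higher from compound 2 to compound 3 (beyond the scatter), both beyond the scatter, showing this position moves the read-out strongly. Among the measured compounds shown here, no measured step introduces a nitro group, so the direction is uncertain. A modest downward step is expected, a number 12.7 percentage points lower from compound 3 to compound 4 (beyond the scatter), with a wide range. In this assay compound 4 is estimated at 40%, between 10% and 65%.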

Compound 4, a percentage reported as inhibition, at one concentration (the size of the read-out at that concentration, not a potency): 43.3%
The estimate for compound 4 lay 3.3 percentage points below the measured number; the measured number falls inside the stated range.
By their numbers in this assay, from the lowest: compound 1; then compounds 2, 4 and 3 (each within the scatter of the next, the first and the last beyond it).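

In this assay, the 4-chloro-3-nitrophenyl group puts a nitro group on the aryl ring at this saturated ring carbon, yet its read-out cannot be told apart from those of two other aryl groups: a number 9.4 percentage points lower from compound 3 to compound 4 (within the scatter) and a number 8.3 percentage points higher from compound 2 to compound 4 (within the scatter). Compound 1 remains separate, with a number 54.3 percentage points higher from compound 1 to compound 4 (beyond the scatter) and the three largest steps at this position all start from compound 1, which carries 2-(trifluoromethyl)phenyl. No available evidence accounts for these numbers.

The compounds shown leave open whether the nitro group or the chlorine of the new aryl group matters more, as neither is varied alone here. How an amine or a carboxylic acid on this aryl ring would read also remains open, and a single-concentration read-out gives no potency for any of these compounds.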